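Methoxy for Phenyl on the Aryl Ketone Side Chain

The source may hold more compounds than are shown below. What is called first, only, known or untested is meant among the compounds shown, and "the series" means these compounds.

Of the compounds shown here, three sharing one core have been tested in a functional assay on SF-539 cells (Homo sapiens) for inhibition, read by sulforhodamine B assay, with a stated time of 48 h, tested at 10 uM; a lower number here means less inhibition of growth, a higher number more inhibition of growth at the concentration tested. Among the measured compounds shown here, compound 1 `CCOC(=O)c1ccc(Nc2ccnc(SCC(=O)c3ccc([N+](=O)[O-])cc3)n2)cc1` gives 11%, and compound 2 `CCOC(=O)c1ccc(Nc2ccnc(SCC(=O)c3ccc(C#N)cc3)n2)cc1` gives 17%; the one measured step, a number 6 percentage points higher from compound 1 to compound 2 (within the scatter), falls within the scatter. Compound 3 `CC(=O)c1cccc(Nc2ccnc(SCC(=O)c3ccc(-c4ccccc4)cc3)n2)c1` gives 11%, the same printed number as compound 1 and close to compound 2, all within the usual scatter of this assay. Compound 4 `COc1ccc(C(=O)CSc2nccc(Nc3cccc(C(C)=O)c3)n2)cc1` differs from compound 3 by methoxy in place of phenyl on an aromatic carbon. For the measured compounds named here, no measured step swaps this particular pair of groups; the only step available, a number 6 percentage points higher from compound 1 to compound 2 (within the scatter), exchanges a different group on an aromatic carbon and stays within the scatter, so no shift beyond the scatter is expected here either. Compound 4 is therefore estimated at 12%, between 0% and 30%, an expected step of a number 1 percentage points higher from compound 3 to compound 4 (within the scatter).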

Compound 4, percent growth inhibition at one concentration: 12%
Compound 4: the middle estimate sits on the measured number at the digits printed; low and high end bracket the measured number.
By their numbers in this assay, from the lowest: compounds 1, 3, 4 and 2 (each within the scatter of the next).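

In this assay, the exchange of phenyl (6 heavy atoms, one ring) for methoxy (2 heavy atoms, no ring, 1 hydrogen-bond acceptor) gives a number 1 percentage points higher from compound 3 to compound 4 (within the scatter). So at this place, para to a large group, a much smaller group that brings a hydrogen-bond acceptor gives a number that cannot be told apart from that of the larger ring. Nothing available here bears on the reason for this result.

The compounds shown leave open whether an amine or a carboxylic acid on this aromatic carbon would move the number beyond the scatter.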